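Hydroxy in place of hydrogen on the phenyl of compound 1

The source may hold more compounds than are shown below. What is called first, only, known or untested is meant among the compounds shown, and "the series" means these compounds.

Compound 1, `CCOC(=O)c1c(-c2ccccc2)[nH]c2cc(OC)ccc2c1=O`, in an ADME assay on HEK293 cells (Homo sapiens) for cytotoxicity, read by luminescence, with a stated time of 72 h; a higher number here means that more compound is needed for the effect, a lower number that less compound is needed: > 22000 nM.
Compound 2, `CCOC(=O)c1c(-c2cccc(OC)c2)[nH]c2cc(OC)ccc2c1=O`, in this assay: > 22000 nM.
Compound 3, `CCOC(=O)c1c(-c2cccc(Oc3ccccc3)c2)[nH]c2cc(OC)ccc2c1=O`, in this assay: > 22000 nM.

Each of these three values is a limit of the assay and not a number. Compound 1 therefore stands at the limit, together with every other value shown, as the limit of > 22000 nM in this assay, at which 3 of the 3 values shown sit, records. Compound 4 is `CCOC(=O)c1c(-c2cccc(O)c2)[nH]c2cc(OC)ccc2c1=O`; it differs from compound 1 by hydroxy in place of hydrogen on an aromatic carbon.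

The measured steps that bear on this position are a step that the two limits leave unreadable from compound 1 to compound 2 and a step that the two limits leave unreadable from compound 1 to compound 3; the exchange of one group for another at the same place, a step that the two limits leave unreadable from compound 2 to compound 3, is likewise unreadable. No size can be read from any of them, since both ends of each sit at the limit. For compound 4 in this assay no step beyond the scatter is expected, and a value again reported only as a limit is the likeliest outcome; the expected step is a step that the limit leaves unreadable from compound 1 to compound 4. The estimate for compound 4 is 30000 nM, with a range from 12000 nM to 80000 nM.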

Compound 4, half-maximal effective concentration: > 22000 nM
Compound 4: no number, only a limit (the forecaster's own chance of this, stated with the estimate: 85%); the middle value does not contradict the limit.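

Compound 4 gives only a limit in this assay, so no step between it and compound 1, compound 2 or compound 3 can be read, and the whole set stands at one limit: the limit of > 22000 nM in this assay, at which 4 of the 4 values shown sit.

Still open, on these data alone, is whether any change on this phenyl brings a readable value in this assay at all.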